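Adding a Hydroxy Group to Compound 2

The compounds below may be only part of what the source reports. "The series", "measured", "known", "first", "only" and "open" are said of these compounds alone.

Of the compounds shown here, three have been measured so far, and their values sit level. In a functional assay on A549 cells (Homo sapiens) for cytotoxicity, read by colorimetric assay and MTT assay (a higher number here means a weaker inhibitor, a lower number a stronger inhibitor), compound 1 `COc1ccc2cc(-c3ccccc3)c(O)nc2c1` gives 10000 nM as its half-maximal inhibitory concentration. In this assay compound 2 `COc1cc(OC)c2cc(-c3ccccc3)c(O)nc2c1` gives 10000 nM as its reading, so it stands level with compound 1. In this assay compound 3 `COc1ccc(-c2cc3cccc(OC)c3nc2O)cc1` gives 10000 nM as well, which leaves compound 2 level with it too.

Compound 4 `COc1cc(OC)c2cc(-c3ccc(O)cc3)c(O)nc2c1` is compound 2 with a single change (hydroxy in place of hydrogen on an aromatic carbon): hydroxy in place of hydrogen on an aromatic carbon, which turns phenyl to 4-hydroxyphenyl. Going by the values given here, the one measured step that bears on it, with methoxy in place of hydrogen on an aromatic carbon, came out as no change at the digits printed from compound 1 to compound 2 (within the scatter) and so shows no movement. Among the compounds with values here, that step brings in a different group, and no measured step adds a hydroxy, so the evidence is indirect. No shift in either direction is therefore expected in this assay for this change, although a real gain in strength cannot be ruled out. The step expected is no change at the digits printed from compound 2 to compound 4 (within the scatter) on this estimate. Compound 4 is expected at 10000 nM with an estimated range of 3000 nM to 20000 nM as matters stand.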

Compound 4, half-maximal inhibitory concentration: 10000 nM
Compound 4: middle estimate and measured number agree at the digits printed, within the range that was stated.
By their numbers in this assay, from the lowest: compounds 1, 2, 3 and 4 (each within the scatter of the next).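

The change from phenyl to 4-hydroxyphenyl, which places a hydroxy on an aromatic carbon para to a large group, reads as no change at the digits printed from compound 2 to compound 4 (within the scatter) in this assay. This is the first direct reading for a hydroxy among these compounds, and the first single-place step on this phenyl ring, since the earlier step, no change at the digits printed from compound 1 to compound 2 (within the scatter), brought in a methoxy on the shared core instead. The added hydroxy, with its hydrogen-bond donor and acceptor, thus leaves the reading level with compound 2 at 10000 nM, and no measurement at hand offers an explanation for this flat result.

On these data alone, it remains open whether a different group at this place, such as an amine, a carboxylic acid or a longer alkoxy chain, would move the reading in this assay. With all four compounds level, nothing shown yet ties any feature to a stronger or weaker reading, and it is also open whether a hydroxy would behave the same way elsewhere on the shared core.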